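Methoxy for Methyl at the Carbonyl of Compound 1

The source may report more compounds than this note shows. Statements on the series, on what has been measured and on what is new or still open speak of the compounds shown alone.

Measured compounds in a functional assay for inhibition of nuclear factor NF-kappa-B complex (Homo sapiens); on this read-out lower numbers stand for stronger inhibition and higher numbers for weaker inhibition:
compound 1 `COc1ccc2c(c1)OC(c1cc(OC)c(OC)c(OC)c1)C(C(C)=O)=C2` gives 14100 nM.
compound 2 `COc1ccc2c(c1)OC(c1cc(OC)c(OC)c(OC)c1)C(C(N)=O)=C2` gives > 50000 nM, a limit of the assay and not a number.
compound 3 `COc1ccc2c(c1)OC(c1cc(OC)c(OC)c(OC)c1)C(C(=O)N(C)OC)=C2` gives 11700 nM.

Compound 1 holds the higher of the two numbers, but compound 3 lies within the scatter of it: a 1.2-fold lower number from compound 1 to compound 3 (0.08 log units; within the scatter). Compound 4 `COC(=O)C1=Cc2ccc(OC)cc2OC1c1cc(OC)c(OC)c(OC)c1` differs from compound 1 by methoxy in place of methyl on a carbonyl carbon. Within the data shown here, two measured steps touch the same carbonyl carbon: a 1.2-fold lower number from compound 1 to compound 3 (0.08 log units; within the scatter), whereas an at least 3.5-fold higher number from compound 1 to compound 2 (0.54 log units; beyond the scatter). The change to compound 4 shares the methoxy group with the step to compound 3, and compound 4 is therefore expected to show a 1.3-fold higher number from compound 1 to compound 4 (0.11 log units; within the scatter), a step not clearly beyond the scatter. Compound 4 is estimated at 18000 nM, within 8000 nM to 45000 nM.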

Compound 4, half-maximal inhibitory concentration: 13800 nM
Estimate against measurement, compound 4: 1.3-fold (0.12 log units) above; the measured number falls inside the stated range.
By their numbers in this assay, from the lowest: compounds 3, 4 and 1 (each within the scatter of the next). At a limit, above all of these: compound 2.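

In this assay methoxy on the carbonyl carbon changes little, with a 1.0-fold lower number from compound 1 to compound 4 (0.01 log units; within the scatter) and with a 1.2-fold higher number from compound 3 to compound 4 (0.07 log units; within the scatter) so methyl, methoxy and methoxy(methyl)amino all sit within the scatter of one another at this place. Among these compounds, only amino goes against this, with an at least 3.6-fold lower number from compound 2 to compound 4 (0.55 log units; beyond the scatter) as the one step here beyond the scatter. Compound 2 stands at a limit of the assay and not a number: the limit of > 50000 nM in this assay, at which 1 of the 4 values shown sits. The compounds shown leave open whether a carboxylic acid or an ethyl ester at this carbonyl carbon would stay with compounds 1, 3 and 4. They also leave open whether any group here could give a clearly lower number.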